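Swapping methoxy for ethyl beside the shared core

The source may hold more compounds than are shown below. What is called first, only, known or untested is meant among the compounds shown, and "the series" means these compounds.

Compound 1 `COC(=O)c1cc(CCc2c(OC)cccc2OC)ccc1O`: 110 nM
Compound 2 `CCc1ccc(OC)c(CCc2ccc(O)c(C(=O)OC)c2)c1`: 430 nM
Compound 3 `CCc1ccc(CC)c(CCc2ccc(O)c(C(=O)OC)c2)c1`: 650 nM

These three compounds were tested in a functional assay on HaCaT cells (Homo sapiens) for antiproliferative activity, read by sulforhodamine B assay, with a stated time of 3 days; a lower number here means a stronger inhibitor, a higher number a weaker inhibitor. Compound 1 gives the lowest number of the three; compound 2 lies a 1.5-fold higher number from compound 2 to compound 3 (0.18 log units; within the scatter) away from compound 3, and compound 1 sits well apart from both. The difference between the core of compound 1 and the core of compound 2 is not broken down here.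

Compound 3 arises from compound 2 by ethyl in place of methoxy on an aromatic carbon, and the same kind of change turns compound 1 into compound 4 `CCc1cccc(OC)c1CCc1ccc(O)c(C(=O)OC)c1`, namely (ethyl in place of methoxy on an aromatic carbon). The surroundings are not identical: in the measured pair the place is para to an ethyl group, whereas in compound 1 it is meta to a methoxy group.

Since the measured example of this change gave only a 1.5-fold higher number from compound 2 to compound 3 (0.18 log units; within the scatter), a step of similar size, a 1.5-fold higher number from compound 1 to compound 4 (0.19 log units; within the scatter), is expected for compound 4. Compound 4 is therefore estimated at 170 nM in this assay, with a likely range from 70 nM to 450 nM.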

Compound 4, half-maximal inhibitory concentration: 200 nM
The estimate for compound 4 lay 1.2-fold (0.07 log units) below the measured number; the range from low to high includes it.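

On the core of compound 1, ethyl in place of methoxy gives, in this assay, a 1.8-fold higher number from compound 1 to compound 4 (0.26 log units; within the scatter). Set beside the earlier case on the other core, the two steps agree: the same change on two cores in this assay, a 1.5-fold higher number (0.18 log units; within the scatter) from compound 2 to compound 3 and a 1.8-fold higher number (0.26 log units; within the scatter) from compound 1 to compound 4, 1.2-fold (0.08 log units) apart, within the scatter of two such steps

So on these two cores the change carried over with no step beyond the usual scatter, which makes the earlier pair a fair guide for the later one; it does not show that ethyl and methoxy are truly equal here, why the numbers behave this way, or that the same would hold on any other core.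

What a longer chain such as propyl, or an amine or a carboxylic acid, would do at this place stays open, as the compounds shown carry only methoxy and ethyl there. Also open, as far as these compounds go, is what separates the core of compound 1 from the core of compound 2, since no single change between them can be read from these compounds.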